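The source may hold more compounds than are shown below. What is called first, only, known or untested is meant among the compounds shown, and "the series" means these compounds.

Compound 1 `CCC1=C(C(=O)OCC2CCCCC2)C(c2cccc(O)c2)NC(=O)N1`: > 10000 nM
Compound 2 `C#CC1=C(C(=O)OCC2CCCCC2)C(c2cccc(O)c2)NC(=O)N1`: > 1000 nM
Compound 3 `O=C1NC(c2ccccc2)=C(C(=O)OCC2CCCCC2)C(c2cccc(O)c2)N1`: > 10000 nM

In an ADME assay on CEMx174 cells (Homo sapiens) for cytotoxicity (on this read-out higher numbers stand for lower toxicity in this test and lower numbers for higher toxicity in this test), compound 1 gives > 10000 nM, which is a limit and not a number. Compound 2 gives > 1000 nM, which is also a limit. Compound 3 gives > 10000 nM, again a limit. Compound 1 therefore stands at the limit of > 10000 nM in this assay, at which 2 of the 3 values shown sit, while compound 2 stands at the limit of > 1000 nM in this assay, at which 1 of the 3 values shown sits. None of the three has a measured number.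

Compound 4 `CCC1=C(C(=O)OCC2CCCCC2)[C@@H](c2cccc(O)c2)NC(=O)N1` has not yet been measured. It keeps the atoms and bonds of compound 1: the two compounds have the same atoms and bonds; at least one stereo element is drawn with a configuration in one of them and without one in the other: 1 of 1 stereo elements differ; a stereocentre at a saturated ring carbon is drawn without a configuration in compound 1 and R in compound 4.

Three measured steps are available: a step that the two limits leave unreadable from compound 1 to compound 2, a step that the two limits leave unreadable from compound 1 to compound 3 and a step that the two limits leave unreadable from compound 2 to compound 3. All three exchange the group on a double-bonded ring carbon, and none touches the stereocentre. Their sizes cannot be read, so they give no measure for this change. The expectation therefore rests on the limit of compound 1 at > 10000 nM, since compound 4 has the same atoms and bonds. No step beyond the scatter is expected in this assay, and so no direction is expected either. The estimated size is a step that the limit leaves unreadable from compound 1 to compound 4. Compound 4 is expected at 15000 nM, with an estimated range from 5000 nM to 50000 nM.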

Compound 4, half-maximal cytotoxic concentration: > 10000 nM
Compound 4 gave a limit, no number; the forecaster's own chance of this, stated with the estimate: 85%; the middle value lies beyond the limit too.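

In this assay compound 4 gives > 10000 nM, which is a limit. Compound 1 gives > 10000 nM, also a limit. Among these compounds, no step can therefore be read between compound 1 and compound 4. The compounds shown leave open how far the R configuration at the saturated ring carbon bears on the read-out in this assay.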